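Halogen Swap on the Anilino Ring: Chloro to Bromo

This account rests on a few compounds, and the source may have more. Where it says the series, first, only, none or still open, it means among the compounds named here.

Compound 1 `O/N=C(/Nc1cccc(Br)c1)c1ccc2oc(COCC3CC3)cc2c1`: 400 nM
Compound 2 `O/N=C(/Nc1cccc(F)c1)c1ccc2oc(-c3ccccc3)cc2c1`: 11000 nM
Compound 3 `O/N=C(/Nc1cccc(Cl)c1)c1ccc2oc(-c3ccccc3)cc2c1`: 900 nM

In an assay on isolated protein for inhibition of Indoleamine 2,3-dioxygenase 1 (Homo sapiens), read by spectrophotometry (on this read-out higher numbers stand for weaker inhibition and lower numbers for stronger inhibition), compound 3 gives 900 nM, the second highest of the three numbers shown: compound 1 lies lower and compound 2 lies higher, both beyond the scatter. Within the data shown here, the only step between measured compounds that differ in one place is a 12-fold lower number from compound 2 to compound 3 (1.09 log units; beyond the scatter). Compound 4 `O/N=C(/Nc1cccc(Br)c1)c1ccc2oc(-c3ccccc3)cc2c1` arises from compound 3 by bromo in place of chloro on an aromatic carbon, the change sitting meta to a large group. Among the measured compounds shown here, no measured pair shows this exact swap. Compound 1 also carries bromo, though elsewhere in the molecule it is built differently, and it gives 400 nM. A step in the same direction as the fluoro-to-chloro change is expected for compound 4, but smaller, because a 12-fold lower number from compound 2 to compound 3 (1.09 log units; beyond the scatter) already covered most of the ground. The expected step is a 2.0-fold lower number from compound 3 to compound 4 (0.30 log units; within the scatter). Compound 4 is therefore estimated to give 450 nM, with a range from 150 nM to 1500 nM.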

Compound 4, half-maximal inhibitory concentration: 900 nM
Estimate against measurement, compound 4: 2.0-fold (0.30 log units) below; low and high end bracket the measured number.
By their numbers in this assay, from the lowest: compound 1; then compounds 3 and 4 (each within the scatter of the next); then compound 2.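

With phenyl on the shared core, bromo in place of chloro on the aromatic carbon brings no change at the digits printed from compound 3 to compound 4 (within the scatter) in this assay and so leaves the two halogens indistinguishable here, while bromo in place of fluoro brings a 12-fold lower number from compound 2 to compound 4 (1.09 log units; beyond the scatter) and matches the large step seen with chloro. Among these three halogens, then, only fluoro stands apart at this position. With bromo held constant, the exchange of (cyclopropylmethoxy)methyl for phenyl brings a 2.3-fold higher number from compound 1 to compound 4 (0.35 log units; beyond the scatter) and shows that the group on the other end of the core also moves the number, though nothing at hand explains either result.

On these data alone, it remains open whether iodo, methyl or methoxy at this position would sit with chloro and bromo or with fluoro. The compounds shown also leave open whether fluoro would fall away in the same manner with (cyclopropylmethoxy)methyl on the core, and how an amine or a carboxylic acid would fare in that place.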